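From Dipropylamino to Diallylamino on a Shared Core

The compounds below may be only part of what the source reports. "The series", "measured", "known", "first", "only" and "open" are said of these compounds alone.

Measured in a functional assay on HepG2 cells (Homo sapiens) for antiproliferative activity, read by MTT assay, with a stated time of 48 h; on this read-out higher numbers stand for weaker inhibition and lower numbers for stronger inhibition:
- Compound 1 `CCNC(=O)Nc1nc(-c2ccc(OCC)cc2)c(-c2cc(OC)c(OC)c(OC)c2)s1`: 30.7 nM
- Compound 2 `CCCN(CCC)c1nc(-c2ccc(OCC)cc2)c(-c2cc(OC)c(OC)c(OC)c2)s1`: > 5000 nM

In this assay compound 2 gives > 5000 nM, which is a limit and not a number. Compound 3 `C=CCN(CC=C)c1nc(-c2ccc(OCC)cc2)c(-c2cc(OC)c(OC)c(OC)c2)s1` keeps the rest of compound 2 and has diallylamino in place of dipropylamino on an aromatic carbon. Going by the values given here, the only measured step that bears on this is large and lies beyond the scatter: an at least 160-fold higher number from compound 1 to compound 2 (2.21 log units; beyond the scatter). It put dipropylamino in place of (ethylcarbamoyl)amino. Compound 3 lacks (ethylcarbamoyl)amino too, so with that step in view, no recovery towards compound 1 is expected in this assay. The expected outcome is a step that the limit leaves unreadable from compound 2 to compound 3, with no change beyond the scatter. For compound 3 the estimate is 6000 nM, with an expected range of 2500 nM to 15000 nM, and a result that is only a limit is likely.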

Compound 3, half-maximal inhibitory concentration: > 5000 nM
Compound 3: a limit, no number (the forecaster's own chance of this, stated with the estimate: 75%); the middle value lies beyond the limit too.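

In this assay compound 3 gives > 5000 nM, which is a limit of the assay and not a number. Diallylamino in place of (ethylcarbamoyl)amino gives an at least 160-fold higher number from compound 1 to compound 3 (2.21 log units; beyond the scatter), so the large loss on this aromatic carbon is no longer tied to dipropylamino alone but is seen with a second replacing group. The step between dipropylamino and diallylamino cannot be read, and any difference between compound 2 and compound 3 stays hidden at the limit: the limit of > 5000 nM in this assay, at which 2 of the 3 values shown sit.

The compounds shown leave open which part of the (ethylcarbamoyl)amino group carries the activity of compound 1: the carbonyl, the amide hydrogen or the ethyl chain. An ethylamino or an acetamido group on the same carbon of the shared core would begin to separate these.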